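The source may hold more compounds than are shown below. What is called first, only, known or untested is meant among the compounds shown, and "the series" means these compounds.

Measured so far:
Compound 1, `CC1CCC(/C=N/c2ccc(C(=O)O)cc2)=C2NC=CC(=O)N21` — in a functional assay on the whole organism with Rattus norvegicus as the target (on this read-out lower numbers stand for an effect already at smaller amounts and higher numbers for an effect only at larger amounts of compound), compound 1 gives > 100 umol/kg, a limit of the assay.
Compound 2, `CCOC(=O)C1=CNC2=C(/C=N/c3ccccc3C(=O)O)CCC(C)N2C1=O` — in this assay compound 2 gives 24.8 umol/kg.
Compound 3, `CCOC(=O)C1=CNC2=C(/C=N/c3cccc(C(=O)O)c3)CCC(C)N2C1=O` — in this assay compound 3 gives 100 umol/kg.

Among the two numbers actually read out, compound 3 stands at the highest, and its nearest neighbour is compound 2, whose number is lower; the only other value shown is a limit (the limit of > 100 umol/kg in this assay, at which 1 of the 3 values shown sits), so compound 3 is placed at the upper edge of what has been measured as a number.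

The next compound, compound 4, `CCOC(=O)C1=CNC2=C(/C=N/c3ccc(C(=O)O)cc3)CCC(C)N2C1=O`, differs from compound 3 only at the aryl group on the double-bonded nitrogen: 4-carboxyphenyl in place of 3-carboxyphenyl on a double-bonded nitrogen.

Among the measured compounds shown here, one measured step bears on this kind of change. Moving the carboxyl from the 2- to the 3-position on the same ring gave a 4.0-fold higher number from compound 2 to compound 3 (0.61 log units; beyond the scatter). Compound 1, which carries the 4-carboxyphenyl group but lacks the ethyl ester of compound 4, sits at the limit of the assay. Taken together, a further move of the carboxyl around the ring is expected to push the number up again, or at least not to lower it, so compound 4 is expected at a 1.5-fold higher number from compound 3 to compound 4 (0.18 log units; within the scatter), which corresponds to an estimated value for compound 4 of 150 umol/kg with a range from 50 umol/kg to 500 umol/kg, and a real chance that only a limit is reported.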

Compound 4, dose for 50% inhibition: 67.1 umol/kg
Compound 4: the middle estimate sits 2.2-fold (0.35 log units) above what was measured; low and high end bracket the measured number.
By their numbers in this assay, from the lowest: compound 2; then compounds 4 and 3 (each within the scatter of the next).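

Moving the carboxyl one place further does not carry on the earlier rise: in this assay the 3-carboxyphenyl and 4-carboxyphenyl groups on the double-bonded nitrogen cannot be told apart, with a 1.5-fold lower number from compound 3 to compound 4 (0.17 log units; within the scatter); what stands out is the 2-carboxyphenyl group, since the 4-carboxyphenyl group also gives up ground to it, with a 2.7-fold higher number from compound 2 to compound 4 (0.43 log units; beyond the scatter). Among these three compounds with the ethoxycarbonyl group, the difference therefore separates compound 2 from the other two rather than forming a steady trend around the ring, and the new compound also gives a first reading of ethoxycarbonyl in place of hydrogen on a double-bonded ring carbon, with an at least 1.4-fold lower number from compound 1 to compound 4 (0.17 log units; that floor lies within the scatter). That reading is only a floor, as compound 1 gives no number but a limit: the limit of > 100 umol/kg in this assay, at which 1 of the 4 values shown sits.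

From the compounds shown here alone, the true size of the ethoxycarbonyl step therefore remains open, as does whether the 2-carboxyphenyl group would keep its lead with hydrogen in that place. Going by these compounds, it is also open how an amide or a hydroxyl in place of the carboxylic acid on the ring, or a longer chain in place of the ethyl of the ester, would read in this assay.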